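Changing one carbonyl substituent of compound 2

A few compounds are considered here, and "the series" means these few. Any claim that something is new, unique, unknown or untested is made for them only; others in the source may bear on it.

Compound 1 (`CCN(CC)CCNC(=O)c1ccc(C(CC)(CC)c2ccc(OCC(=O)C(C)(C)C)c(C)c2)n1CC`) gives 690 nM
Compound 2 (`CCOC(=O)CN(C)C(=O)c1ccc(C(CC)(CC)c2ccc(OCC(O)C(C)(C)C)c(C)c2)n1CC`) gives 9200 nM

In a functional assay on MCF7 cells (Homo sapiens), read by MTT assay, with a stated time of 48 h (on this read-out higher numbers stand for weaker inhibition and lower numbers for stronger inhibition), compound 2 has the higher of the two numbers, and its gap to compound 1 lies beyond the usual scatter. Compound 3 (`CCN(CC)CCNC(=O)c1ccc(C(CC)(CC)c2ccc(OCC(O)C(C)(C)C)c(C)c2)n1CC`) carries (2-(diethylamino)ethyl)amino in place of ((ethoxycarbonyl)methyl)(methyl)amino on a carbonyl carbon. For the measured compounds named here, no measured pair shows this change alone. Compound 1 (at 690 nM) also carries (2-(diethylamino)ethyl)amino, so a lower number, beyond the scatter, is expected in this assay for compound 3. The estimated change is a 7.1-fold lower number from compound 2 to compound 3 (0.85 log units; beyond the scatter) (an expectation only). Compound 3 is expected at 1300 nM (estimated range 400 nM to 4000 nM).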

Compound 3, half-maximal inhibitory concentration: 690 nM
Beside the measured number, compound 3's estimate is 1.9-fold (0.28 log units) above it; low and high end bracket the measured number.
By their numbers in this assay, from the lowest: compounds 1 and 3 (each within the scatter of the next); then compound 2.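

In this assay putting (2-(diethylamino)ethyl)amino in place of ((ethoxycarbonyl)methyl)(methyl)amino on the carbonyl carbon gives a 13-fold lower number from compound 2 to compound 3 (1.12 log units; beyond the scatter) and so shows that this substituent matters strongly. Putting 1-hydroxy-2,2-dimethylpropyl in place of (tert-butyl)carbonyl gives no change at the digits printed from compound 1 to compound 3 (within the scatter) and so shows that, with this amine chain in place, the two groups read alike. Still open, on these data alone, is whether a piperidine ring in place of the diethylamino group, or a longer chain leading to that nitrogen, would keep the number. No measurement shown here explains the large step.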